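This account rests on a few compounds, and the source may have more. Where it says the series, first, only, none or still open, it means among the compounds named here.

Measured compounds and their values:

compound 1 `Cc1ccc2[nH]c3c(c2c1)CC[C@]1(C3=O)[C@@H](c2ccccc2)[C@@H](c2ccccc2)N[C@@]12C(=O)Nc1ccccc12` — 18000 nM
compound 2 `O=C1Nc2ccccc2[C@]12N[C@H](c1ccccc1)[C@H](c1ccccc1)[C@@]21CCc2c([nH]c3ccc(Cl)cc23)C1=O` — 15000 nM
compound 3 `O=C1Nc2ccccc2[C@]12N[C@H](c1ccccc1)[C@H](c1ccccc1)[C@@]21CCc2c([nH]c3ccccc23)C1=O` — 17000 nM

The three measured compounds share one core and differ only in the group on an aromatic carbon, where compound 1 carries a methyl, compound 2 a chloro and compound 3 a hydrogen. In a functional assay on A549 cells (Homo sapiens) for antiproliferative activity, read by MTT assay, with a stated time of 48 h (a lower number here means a stronger inhibitor, a higher number a weaker inhibitor), compound 1 gives the largest of the three numbers, but the steps to its neighbours are small: a 1.1-fold lower number from compound 1 to compound 3 (0.02 log units; within the scatter) and a 1.2-fold lower number from compound 1 to compound 2 (0.08 log units; within the scatter), both within the scatter, as is a 1.1-fold higher number from compound 2 to compound 3 (0.05 log units; within the scatter). The three are therefore not distinguished by this assay.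

Compound 4 `COc1ccc([C@H]2[C@@H](c3ccccc3)N[C@@]3(C(=O)Nc4ccccc43)[C@]23CCc2c([nH]c4ccc(C)cc24)C3=O)cc1` is unmeasured. It differs from compound 1 by methoxy in place of hydrogen on an aromatic carbon. Going by the values given here, none of the measured steps touches that phenyl; they concern a different aromatic carbon on the core. Among the compounds with values here, they bear on the expectation only in a general way: exchanges of small groups on this core left this assay unmoved, and nothing among the measured compounds points to a step beyond the scatter for this change either. The expected step is no change at the digits printed from compound 1 to compound 4 (within the scatter). Compound 4 is therefore estimated to give about 18000 nM in this assay, with a range from 9000 nM to 36000 nM.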

Compound 4, half-maximal inhibitory concentration: 20000 nM
Beside the measured number, compound 4's estimate is 1.1-fold (0.05 log units) below it; the measured number falls inside the stated range.
By their numbers in this assay, from the lowest: compounds 2, 3, 1 and 4 (each within the scatter of the next).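

The first change away from the aromatic carbon varied among compounds 1, 2 and 3 is phenyl to 4-methoxyphenyl, which in this assay gives a 1.1-fold higher number from compound 1 to compound 4 (0.05 log units; within the scatter). Going by these compounds alone, a second place on the shared core, on a different ring, therefore joins the first in showing no step beyond the scatter, and the four compounds remain undistinguished by this assay, whether the change lies on the core's aromatic carbon or on this phenyl. No evidence is at hand that accounts for this flat picture.

Among the compounds shown, methoxy is the only group on this phenyl, so it remains open whether an amine, a carboxylic acid or a longer chain such as butoxy, para to the same large group, would give a step beyond the scatter. Also open, as far as these compounds go, is whether changes elsewhere on the shared core, such as at the second phenyl or the amide hydrogen, would separate any compound from the others in this assay.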